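A few compounds are considered here, and "the series" means these few. Any claim that something is new, unique, unknown or untested is made for them only; others in the source may bear on it.

Working notes on the series. In a functional assay on K562 cells (Homo sapiens) for cytotoxicity, read by MTT assay, with a stated time of 72 h (a lower number here means a stronger inhibitor, a higher number a weaker inhibitor), compound 1 `C=C1C2=C(C(=O)N1OC)[C@H](OC(=O)CSc1nc3ccccc3s1)[C@@](C)(O)[C@H](CCCCC)O2` gives 4300 nM, the lowest of the two numbers in hand; compound 2 `C=C1C2=C(C(=O)N1OC)[C@@H](F)[C@@](C)(O)[C@H](CCCCC)O2` gives 18000 nM, a markedly higher number in this assay, beyond the scatter. Compound 3 `C=C1C2=C(C(=O)N1OC)[C@H](OC(=O)CSc1nc3ccccc3[nH]1)[C@@](C)(O)[C@H](CCCCC)O2` is not yet measured; it differs from compound 1 only in the ester-linked side group: 1H-benzimidazol-2-yl in place of 1,3-benzothiazol-2-yl on a sulfur. For the measured compounds named here, no measured pair carries this particular change, so the expectation rests on compound 1 alone, and the expected step is a 1.2-fold higher number from compound 1 to compound 3 (0.07 log units; within the scatter), not beyond the scatter. Compound 3 is expected to give 5000 nM, within a range from 2000 nM to 13000 nM.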

Compound 3, half-maximal inhibitory concentration: 9300 nM
Compound 3: the middle estimate sits 1.9-fold (0.27 log units) below what was measured, and the stated range covers the measured number.
By their numbers in this assay, from the lowest: compound 1; then compounds 3 and 2 (each within the scatter of the next).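

The side group on the sulfur is not a neutral site in this assay: 1H-benzimidazol-2-yl in place of 1,3-benzothiazol-2-yl gives a 2.2-fold higher number from compound 1 to compound 3 (0.34 log units; beyond the scatter), a modest step but beyond the scatter. For the compounds shown here, it is the only reading so far at this position, so the two groups cannot be treated as interchangeable here. Nothing measured bears on why the number rises.

As far as these compounds go, whether a phenyl or a pyridin-2-yl group on the sulfur would match compound 1 stays open. So does whether a methyl on the benzimidazole ring nitrogen would change the step.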